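This account rests on a few compounds, and the source may have more. Where it says the series, first, only, none or still open, it means among the compounds named here.

Compound 1 `O=S(=O)(NCCNC(=S)Nc1cc(C(F)(F)F)cc(C(F)(F)F)c1)c1ccc(-c2ccccc2OCc2cccc(O)c2)s1`: 14900 nM
Compound 2 `O=C(Nc1cccc([N+](=O)[O-])c1)N1CCN(S(=O)(=O)c2sccc2-c2ccccc2Oc2ccc(O)c(O)c2)CC1`: > 20000 nM, a limit
Compound 3 `COc1cccc(NC(=O)NCCNS(=O)(=O)c2ccc(-c3ccccc3OCc3ccccc3)s2)c1`: > 50000 nM, a limit

In a functional assay on HeLa cells (Homo sapiens) for inhibition, read by CCK-8 assay, with a stated time of 48 h (a higher number here means a weaker inhibitor, a lower number a stronger inhibitor), compound 1 is the only one of the three with an actual number; the other two values are limits. Compound 4 `O=S(=O)(NCCNC(=S)Nc1cc(C(F)(F)F)cc(C(F)(F)F)c1)c1ccc(-c2ccccc2OCc2ccccc2)s1` is compound 1 with hydrogen in place of hydroxy on an aromatic carbon, 3-hydroxybenzyl becoming benzyl: hydrogen in place of hydroxy on an aromatic carbon. Within the data shown here, no measured pair isolates this change, so no step beyond the scatter is expected in this assay, and neither direction is favoured. The upper end stays wide: compound 3, also a benzyloxy compound though different elsewhere, reads > 50000 nM, a limit. The expected change is a 1.1-fold lower number from compound 1 to compound 4 (0.06 log units; within the scatter). For compound 4 the estimated value is 13000 nM, with an expected range of 5500 nM to 32000 nM.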

Compound 4, half-maximal inhibitory concentration: 4700 nM
Compound 4: middle estimate off by 2.8-fold (0.44 log units), on the high side, and the stated range ends above it.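

Replacing the hydroxy with hydrogen, 3-hydroxybenzyl becoming benzyl, gives a 3.2-fold lower number from compound 1 to compound 4 (0.50 log units; beyond the scatter), the only step shown that isolates one change. In this assay, the hydroxy at this position is therefore not needed for inhibition, and the plain benzyl gives the lower number of the pair. Nothing measured among the compounds shown accounts for this step.

Still open, as far as these compounds go, is whether any group at this position raises the number or whether this applies to hydroxy alone. A methoxy, a fluorine or an amine in the same place would separate these two readings.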